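The compounds below may be only part of what the source reports. "The series", "measured", "known", "first", "only" and "open" are said of these compounds alone.

In a functional assay on HeLa cells (Homo sapiens) for antiproliferative activity, read by MTT assay, with a stated time of 72 h (on this read-out lower numbers stand for stronger inhibition and higher numbers for weaker inhibition), compound 3 `Cc1ccc(N2CCN(C(=S)SCc3ccc4nc(N)nc(N)c4c3)CC2)cc1` gives 2130 nM and compound 2 `COc1ccc(N2CCN(C(=S)SCc3ccc4nc(N)nc(N)c4c3)CC2)cc1` gives 1660 nM, while compound 1 `Nc1nc(N)c2cc(CSC(=S)N3CCN(c4ccc(O)cc4)CC3)ccc2n1` gives 5180 nM. Compound 3 thus stands with compound 2, as a 1.3-fold higher number from compound 2 to compound 3 (0.11 log units; within the scatter) shows, and apart from compound 1, as a 2.4-fold lower number from compound 1 to compound 3 (0.39 log units; beyond the scatter) shows. Compound 4 `Cc1ccc(N2CCN(C(=S)SCc3ccc4nc(N)nc(N)c4c3)CC2)c(C)c1` carries a methyl in place of hydrogen on an aromatic carbon, ortho to a large group and meta to a methyl group: methyl in place of hydrogen on an aromatic carbon. Within the data shown here, no measured step adds a methyl at this place. The closest evidence is the swaps at another place on that ring, where a 3.1-fold lower number from compound 1 to compound 2 (0.49 log units; beyond the scatter) was modest. On that evidence, no step beyond the scatter is expected in this assay. The expected move is a 1.1-fold lower number from compound 3 to compound 4 (0.05 log units; within the scatter). Compound 4 is estimated at 1900 nM, with an expected range from 850 nM to 4200 nM.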

Compound 4, half-maximal inhibitory concentration: 3190 nM
Compound 4: middle estimate off by 1.7-fold (0.23 log units), on the low side; measured number inside the range.
By their numbers in this assay, from the lowest: compounds 2, 3, 4 and 1 (each within the scatter of the next, the first and the last beyond it).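

In this assay, among these compounds, a methyl on the aromatic carbon ortho to a large group stays within the scatter of the compound without it, with a 1.5-fold higher number from compound 3 to compound 4 (0.18 log units; within the scatter) as the only step at this place. The 2,4-dimethylphenyl group also stays within the scatter of both other aryl groups, with a 1.9-fold higher number from compound 2 to compound 4 (0.28 log units; within the scatter) and a 1.6-fold lower number from compound 1 to compound 4 (0.21 log units; within the scatter) in the same assay, although compound 1 and compound 2 lie beyond the scatter of each other. Nothing measured here accounts for these numbers. From the compounds shown here alone, it remains open whether ethyl, fluorine or an amine at this place would give a step beyond the scatter.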